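The source may report more compounds than this note shows. Statements on the series, on what has been measured and on what is new or still open speak of the compounds shown alone.

Compound 1 `CCCc1nc(C(C)(C)O)c(C(=O)NCCNCCO)n1Cc1ccc(-c2ccccc2C2=NNNN2)cc1` gives 98.9% in an ADME assay on a cell-free system (plasma, Rattus norvegicus, strain Sprague-Dawley) for metabolic stability, with a stated time of 30 min, tested at 50 mg/mL; on this read-out lower numbers stand for a less stable compound and higher numbers for a more stable compound; compound 2 `CCCCCCCCOC(=O)c1c(C(C)(C)O)nc(CCC)n1Cc1ccc(-c2ccccc2C2=NNNN2)cc1` gives 90.2%.

Compound 1 stands highest of the two numbers shown, with compound 2 nearest at a gap within the scatter. Compound 3 `CCCc1nc(C(C)(C)O)c(C(=O)OCCCCCCC(=O)O)n1Cc1ccc(-c2ccccc2C2=NNNN2)cc1` is not yet measured and differs from compound 1 by (6-carboxyhexyl)oxy in place of (2-((2-hydroxyethyl)amino)ethyl)amino on a carbonyl carbon. For the measured compounds named here, the one measured step that bears on this, octyloxy in place of (2-((2-hydroxyethyl)amino)ethyl)amino on a carbonyl carbon, is a number 8.7 percentage points lower from compound 1 to compound 2 (within the scatter). A step of similar size, within the scatter, is expected for a number 10.9 percentage points lower from compound 1 to compound 3 (beyond the scatter). Compound 3 is therefore expected to give about 88%, estimated between 65% and 99%.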

Compound 3, percent of the compound remaining: 98.8%
The estimate for compound 3 lay 10.8 percentage points below the measured number; the range from low to high includes it.
By their numbers in this assay, from the lowest: compounds 2, 3 and 1 (each within the scatter of the next).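

In this assay, (6-carboxyhexyl)oxy in place of (2-((2-hydroxyethyl)amino)ethyl)amino on the carbonyl carbon gives a number 0.1 percentage points lower from compound 1 to compound 3 (within the scatter), so this read-out does not tell these two chains apart. Carboxy in place of ethyl on a saturated chain carbon gives a number 8.6 percentage points higher from compound 2 to compound 3 (within the scatter), so the two oxygen-linked chains are not told apart either. Nothing measured here speaks to a cause. Still open is whether a short methyl ester, a free carboxylic acid on the carbonyl carbon, or a chain ending in a primary amine would stay within the scatter of these compounds.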